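Compound 2 and a step to phenethyl

This account rests on a few compounds, and the source may have more. Where it says the series, first, only, none or still open, it means among the compounds named here.

- compound 1 `CCCCCCCCC#Cc1cn(C/C=C\CN2C(=O)c3ccccc3C2=O)c(=O)[nH]c1=O`: 39000 nM
- compound 2 `O=C1c2ccccc2C(=O)N1C/C=C\Cn1cc(C#Cc2ccc(Br)cc2)c(=O)[nH]c1=O`: 89000 nM
- compound 3 `CCCCc1ccc(C#Cc2cn(C/C=C/CN3C(=O)c4ccccc4C3=O)c(=O)[nH]c2=O)cc1`: 9100 nM

In a functional assay on HepG2 cells (Homo sapiens) for antiproliferative activity, read by MTT assay, with a stated time of 3 days (on this read-out higher numbers stand for weaker inhibition and lower numbers for stronger inhibition), compound 2 gives the highest number of the three, 89000 nM, and so is the weakest of this small set. Its nearest neighbour is compound 1 at 39000 nM, and the furthest is compound 3 at 9100 nM.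

The next compound is compound 4 `O=C1c2ccccc2C(=O)N1C/C=C\Cn1cc(C#CCCc2ccccc2)c(=O)[nH]c1=O`, which carries phenethyl in place of 4-bromophenyl on a triple-bonded carbon. Cut one bond further out, the same difference reads 2-(4-bromophenyl)ethynyl to 4-phenylbut-1-yn-1-yl.

Among the measured compounds shown here, only one measured step bears directly on this change: a 2.3-fold higher number from compound 1 to compound 2 (0.36 log units; beyond the scatter). That step swapped octyl for 4-bromophenyl at the same place, and it was modest. Compound 4 gives up 4-bromophenyl as well, but for a carbon chain ending in phenyl, so it may move partway back toward compound 1 at 39000 nM. One step is thin support, and compound 3 offers no single-change comparison here.

A modest fall in this assay is therefore expected, estimated as a 2.1-fold lower number from compound 2 to compound 4 (0.33 log units; beyond the scatter). For compound 4 the estimated value is 42000 nM, with an expected range of 17000 nM to 100000 nM.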

Compound 4, half-maximal inhibitory concentration: > 100000 nM
Compound 4 ended at the assay's limit; the forecaster's own chance of this, stated with the estimate: 10%; middle value at least 2.3-fold (0.37 log units) away from the limit.
By their numbers in this assay, from the lowest: compound 3; then compound 1; then compound 2. At a limit, above all of these: compound 4.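

In this assay compound 4 gives no number, only a limit: the limit of > 100000 nM in this assay, at which 1 of the 4 values shown sits.

Even so, the step to it from the octyl compound can be read, an at least 2.5-fold higher number from compound 1 to compound 4 (0.40 log units; beyond the scatter), so a saturated chain ending in phenyl does not bring this position back to the level of octyl, and the earlier compounds had not shown that moving the ring away from the triple-bonded carbon fails to do so. The other step, an at least 1.1-fold higher number from compound 2 to compound 4 (0.05 log units; that floor lies within the scatter), gives only a floor within the scatter, so the limit does not separate phenethyl from 4-bromophenyl, and both ring-bearing groups stay on the weaker side of octyl in these single-change comparisons, while compound 3, which also carries a ring but differs in more than one place, gives a lower number and stands outside that comparison.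

From the compounds shown here alone, how far compound 4 actually lies beyond the limit stays unknown, so the size of the change from 4-bromophenyl to phenethyl remains open. Also open, going by these compounds, is what an amine, a carboxylic acid or a longer chain ending in phenyl would do in place of phenethyl on this triple-bonded carbon.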